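Bromo for methyl at the ring of compound 2

The source may hold more compounds than are shown below. What is called first, only, known or untested is meant among the compounds shown, and "the series" means these compounds.

Of the compounds shown here, two sharing one core have been measured in a functional assay on L1210 cells (Mus musculus) for inhibition; on this read-out higher numbers stand for weaker inhibition and lower numbers for stronger inhibition. Compound 1 `O=C1/C(=C/c2ccccc2[N+](=O)[O-])CCc2ccccc21` gives 10800 nM. Compound 2 `Cc1ccccc1/C=C1\CCc2ccccc2C1=O` gives 50200 nM, the highest of the two numbers, so compound 2 shows the weaker inhibition of the pair. Within the data shown here, the single measured step, a 4.6-fold higher number from compound 1 to compound 2 (0.67 log units; beyond the scatter), replaces nitro with methyl on an aromatic carbon and lies beyond the scatter.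

Compound 3 `O=C1/C(=C/c2ccccc2Br)CCc2ccccc21` has not yet been measured. Its change from compound 2 is bromo in place of methyl on an aromatic carbon. Among the measured compounds shown here, no measured step exchanges methyl for bromo, so the only guidance is the step from compound 1 to compound 2, which shows that a single small group on this aromatic carbon can shift this assay beyond the scatter. Bromo is neither of the two groups already seen, so the direction of its effect rests on no direct evidence. A modest step, expected to be a 2.0-fold lower number from compound 2 to compound 3 (0.30 log units; within the scatter), toward lower numbers than compound 2 is estimated, with wide uncertainty. Compound 3 is therefore expected to give 25000 nM, in a range from 8000 nM to 80000 nM.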

Compound 3, half-maximal inhibitory concentration: 33400 nM
For compound 3 the middle estimate is 1.3-fold (0.13 log units) below the measured one, and the stated range covers the measured number.
By their numbers in this assay, from the lowest: compound 1; then compounds 3 and 2 (each within the scatter of the next).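

Exchanging methyl for bromo at this aromatic carbon, ortho to a large group, gives a 1.5-fold lower number from compound 2 to compound 3 (0.18 log units; within the scatter) in this assay, so on this read-out the two groups are not told apart. Bromo in place of nitro gives a 3.1-fold higher number from compound 1 to compound 3 (0.49 log units; beyond the scatter) and thus resembles the earlier exchange of nitro for methyl, which gave a 4.6-fold higher number from compound 1 to compound 2 (0.67 log units; beyond the scatter) as well: of the three groups seen at this carbon, nitro alone stands apart, and compound 1 shows the strongest inhibition of the set. Nothing available on these compounds accounts for this separation of nitro from methyl and bromo.

Among these compounds, with only three groups seen at this one carbon, it remains open whether an amine, a methoxy group or a carboxylic acid there would fall with nitro, with methyl and bromo, or apart from both. Going by these compounds, it also remains open whether nitro, methyl and bromo would keep this same relation at any other carbon of this aromatic ring, or on a core other than the shared one.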